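Mirror-Image Urea and Its Expected Whole-Organism Read-Out

This account rests on a few compounds, and the source may have more. Where it says the series, first, only, none or still open, it means among the compounds named here.

compound 1, `C[C@@H](NC(=O)Nc1cccc(Cl)c1)c1ccccc1`: 91%
compound 2, `C[C@H](NC(=O)Nc1cccc(Cl)c1)c1ccccc1`: 99%
compound 3, `C[C@@H](NC(=O)Nc1ccc(Cl)c(Cl)c1)c1ccccc1`: 96%

These three ureas were tested in an ADME assay on the whole organism with Oryza sativa as the target, tested at 1 uM; a higher number here means a weaker effect of the compound at the concentration tested, a lower number a stronger effect. Going by the values given here, compound 1 gives 91%, compound 2 gives 99% and compound 3 gives 96%; the three numbers lie close together, and none of the measured steps reaches beyond the usual scatter. The step of a number 5 percentage points higher from compound 1 to compound 3 (within the scatter) introduces a chloro group and changes little. The step of a number 8 percentage points higher from compound 1 to compound 2 (within the scatter) is the one that matters most here: due to the fact that compounds 1 and 2 differ only in the configuration as drawn it shows what a swap of the drawn configuration alone does in this measurement, namely a small shift that stays within the scatter.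

Among the compounds with values here, compound 4, `C[C@H](NC(=O)Nc1ccc(Cl)c(Cl)c1)c1ccccc1`, has not yet been measured. the two compounds have the same atoms and bonds and differ only in configuration as drawn: 1 of 1 stereo elements differ; a stereocentre at a saturated chain carbon is drawn R in compound 3 and S in compound 4 This is the same kind of change as the one from compound 1 to compound 2, so that step is the only guide. A small step, leaning slightly upward but not beyond the scatter, is expected. For compound 4 in this assay a value of 98% is therefore estimated, with a range from 90% to 105%. The expected step of a number 2 percentage points higher from compound 3 to compound 4 (within the scatter) is small.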

Compound 4, a percentage reported as activity, at one concentration (the size of the read-out at that concentration, not a potency): 97%
Compound 4: middle estimate off by 1 percentage points, on the high side; measured number inside the range.
By their numbers in this assay, from the lowest: compounds 1, 3, 4 and 2 (each within the scatter of the next).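

On the core with two chloro groups, the step of a number 1 percentage points higher from compound 3 to compound 4 (within the scatter) in this assay repeats for the drawn configuration what the step of a number 8 percentage points higher from compound 1 to compound 2 (within the scatter) showed on the core with one chloro group, so the swap has now been read on two cores, and this reading concerns configuration alone: the fact that compounds 3 and 4 differ only in the configuration as drawn

The chloro in place of hydrogen on an aromatic carbon can also now be read a second time, as the step of a number 2 percentage points lower from compound 2 to compound 4 (within the scatter), and the two readings of that change compare as follows: the same change on two cores in this assay, a number 5 percentage points higher (within the scatter) from compound 1 to compound 3 and a number 2 percentage points lower (within the scatter) from compound 2 to compound 4, 7 percentage points apart, within the scatter of two such steps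

Neither change therefore moves the number beyond the scatter on either core, which means that at this one concentration the four compounds do not separate from one another through configuration or through the added chloro group.

These compounds leave open whether any change at these places can move the read-out beyond the scatter at all. A methoxy group or a nitrile in place of chloro on an aromatic carbon, or a longer chain at the stereocentre, would be needed to test that, since two chloro patterns and two drawn configurations cover only a narrow range of structures.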